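The source may hold more compounds than are shown below. What is called first, only, known or untested is meant among the compounds shown, and "the series" means these compounds.

Compound 1 `CC/C=C\C/C=C\C/C=C\C/C=C\C/C=C\C/C=C\CCC(=O)Nc1ccccc1C(C)C`: 6500 nM
Compound 2 `CC/C=C\C/C=C\C/C=C\C/C=C\C/C=C\C/C=C\CCC(=O)Oc1ccccc1`: > 25000 nM, a limit

Among the compounds with values here, in a functional assay on MDA-MB-231 cells (Homo sapiens) for inhibition, read by WST assay, with a stated time of 48 h (a lower number here means a stronger inhibitor, a higher number a weaker inhibitor), compound 1 gives 6500 nM, the only actual number available so far. Compound 2 reads > 25000 nM, which is a limit of the assay and not a number.

Compound 3 `CC/C=C\C/C=C\C/C=C\C/C=C\C/C=C\C/C=C\CCC(=O)Nc1c(C(C)C)cccc1C(C)C` differs from compound 1 by isopropyl in place of hydrogen on an aromatic carbon, going from 2-isopropylphenyl to 2,6-diisopropylphenyl. Within the data shown here, the one measured step, an at least 3.8-fold higher number from compound 1 to compound 2 (0.58 log units; beyond the scatter), puts phenoxy in place of (2-isopropylphenyl)amino on a carbonyl carbon. It therefore bears only loosely on the new change, since compound 2 keeps no amide and no isopropyl group. Among the measured compounds shown here, no measured step tests a second isopropyl group, so no direction can be drawn from the data, and no shift beyond the scatter is expected in this assay. The expected change is no change at the digits printed from compound 1 to compound 3 (within the scatter). For compound 3 the estimated value is 6500 nM, with an expected range from 2200 nM to 20000 nM.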

Compound 3, half-maximal inhibitory concentration: 3700 nM
The estimate for compound 3 lay 1.8-fold (0.24 log units) above the measured number, within the range that was stated.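

In this assay, adding the second isopropyl group, which turns 2-isopropylphenyl into 2,6-diisopropylphenyl, gives a 1.8-fold lower number from compound 1 to compound 3 (0.24 log units; within the scatter) and so stays inside the usual scatter. Within the data shown here, this aromatic carbon therefore takes an isopropyl group with no shift that can be told from noise, something the earlier compounds could not show, as their only step replaced the whole amide side with a phenyl ester. Nothing shown here offers a cause for this step.

Going by these compounds, whether a methyl group, a methoxy group or an amine on this same carbon would also leave the number within the scatter remains open. Also open, on these data alone, is whether a shorter chain in place of the long polyunsaturated one would keep the measured number of the 2,6-diisopropylphenyl amide.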